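The source may report more compounds than this note shows. Statements on the series, on what has been measured and on what is new or still open speak of the compounds shown alone.

Measured compounds:
compound 1 `CN(C)CCNc1nc(-c2ccc(NC(=O)Nc3ccc(Cl)cc3)cc2)nc2ccsc12` — 310 nM
compound 2 `CCN(CC)CCCNc1nc(-c2ccc(NC(=O)Nc3ccc(F)cc3)cc2)nc2ccsc12` — 530 nM
compound 3 `CCN(CC)CCCNc1nc(-c2ccc(NC(=O)Nc3ccccc3F)cc2)nc2ccsc12` — 860 nM

In a functional assay on MDA-MB-231 cells (Homo sapiens) for cytotoxicity, read by MTT assay, with a stated time of 72 h (on this read-out lower numbers stand for stronger inhibition and higher numbers for weaker inhibition), compound 3 gives the highest of the three numbers. Its nearest neighbour is compound 2, and the step of a 1.6-fold higher number from compound 2 to compound 3 (0.21 log units; within the scatter) lies within the scatter, so the two cannot be ordered. Compound 1 stands further off; in this assay compound 1 gives 310 nM, and that gap to compound 3 is beyond the scatter.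

Compound 4 `CCN(CC)CCCNc1nc(-c2ccc(NC(=O)Nc3ccc(Cl)cc3)cc2)nc2ccsc12` has not yet been measured. It differs from compound 3 in one place: 4-chlorophenyl in place of 2-fluorophenyl on an amide-type nitrogen. Within the data shown here, of the measured steps, only the step from compound 2 to compound 3 touches this position, and a 1.6-fold higher number from compound 2 to compound 3 (0.21 log units; within the scatter) was within the scatter. Among the measured compounds shown here, compound 1 carries the same 4-chlorophenyl group as compound 4 but a different chain on the other side of the core, so no single-change step connects it to compound 4; its value shows only that the 4-chlorophenyl group is compatible with a number at the lower end of the three.

Compound 4 is therefore expected to land near compound 2, which in this assay gives 530 nM, with a step of a 1.9-fold lower number from compound 3 to compound 4 (0.28 log units; within the scatter) that is at most modestly downward. The estimate for compound 4 in this assay is 450 nM, with a likely range from 200 nM to 1000 nM.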

Compound 4, half-maximal inhibitory concentration: 230 nM
Estimate against measurement, compound 4: 2.0-fold (0.29 log units) above; the measured number falls inside the stated range.
By their numbers in this assay, from the lowest: compounds 4, 1, 2 and 3 (each within the scatter of the next, the first and the last beyond it).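

In this assay, among these compounds, the group on the amide-type nitrogen now shows a readable change: 4-chlorophenyl in place of 2-fluorophenyl gives a 3.7-fold lower number from compound 3 to compound 4 (0.57 log units; beyond the scatter), whereas the only earlier step at this position, a 1.6-fold higher number from compound 2 to compound 3 (0.21 log units; within the scatter), could not be ordered. Changing the halogen alone, with chloro in place of fluoro on an aromatic carbon, gives a 2.3-fold lower number from compound 2 to compound 4 (0.36 log units; beyond the scatter), so this single change is enough to move the number, though only modestly. With 4-chlorophenyl held constant, (diethylamino)methyl in place of dimethylamino gives a 1.3-fold lower number from compound 1 to compound 4 (0.13 log units; within the scatter), so the two chains cannot be ordered in this pair. Nothing at hand gives a reason for these steps.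

A 2-chlorophenyl group on the same nitrogen would show how much of the larger step belongs to the halogen and how much to its place on the ring. Going by these compounds, it also remains open whether a 4-bromophenyl or 4-methoxyphenyl group would give a lower or higher number than 4-chlorophenyl, and whether a longer chain carrying the diethylamino group would leave the number unchanged.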